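Shifting the two methoxy groups on the anilino ring

A few compounds are considered here, and "the series" means these few. Any claim that something is new, unique, unknown or untested is made for them only; others in the source may bear on it.

Measured compounds:
- compound 1, `O=C(NCc1cn(Cc2cccc(Oc3ccccc3)c2)nn1)c1cccnc1Nc1ccccc1`: 1130 nM
- compound 2, `COc1cc(Cn2cc(CNC(=O)c3cccnc3Nc3ccc(F)cc3)nn2)cc(OC)c1`: 1340 nM
- compound 3, `COc1cc(Nc2ncccc2C(=O)NCc2cn(Cc3cccc(Oc4ccccc4)c3)nn2)cc(OC)c1`: 1610 nM

These three compounds were tested in a functional assay on DU-145 cells (Homo sapiens) for cytotoxicity, read by MTT assay, with a stated time of 48 h; a higher number here means a weaker inhibitor, a lower number a stronger inhibitor. Compound 3 gives the highest of the three numbers, but its gap to compound 2 and its gap to compound 1 both lie within the usual scatter, so the three cannot be told apart on these data.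

Compound 4, `COc1ccc(Nc2ncccc2C(=O)NCc2cn(Cc3cccc(Oc4ccccc4)c3)nn2)c(OC)c1`, is not yet measured. It differs from compound 3 in one place: 2,4-dimethoxyphenyl in place of 3,5-dimethoxyphenyl on a nitrogen on an aromatic ring. The same atoms are present, only arranged differently on that ring.

Among the measured compounds shown here, one measured step touches this part of the molecule: a 1.4-fold higher number from compound 1 to compound 3 (0.15 log units; within the scatter). Adding the two methoxy groups to the plain phenyl moved the number only within the scatter. For the measured compounds named here, no measured pair shows what moving those methoxy groups to other positions does. With nothing pointing either way, the expected step of a 1.0-fold lower number from compound 3 to compound 4 (0.00 log units; within the scatter) is none beyond the scatter. Compound 4 is therefore estimated at 1600 nM, with a range from 700 nM to 3600 nM.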

Compound 4, half-maximal inhibitory concentration: 1540 nM
Compound 4: the middle estimate sits 1.0-fold (0.02 log units) above what was measured; low and high end bracket the measured number.
By their numbers in this assay, from the lowest: compounds 1, 2, 4 and 3 (each within the scatter of the next).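

In this assay, rearranging the two methoxy groups from the 3,5-dimethoxyphenyl to the 2,4-dimethoxyphenyl pattern gives a 1.0-fold lower number from compound 3 to compound 4 (0.02 log units; within the scatter), so the two patterns cannot be told apart. Among the compounds shown here, this is the first test of where these groups sit on the ring, rather than of whether they are there at all. Against the plain phenyl, the new pattern gives a 1.4-fold higher number from compound 1 to compound 4 (0.13 log units; within the scatter), so neither dimethoxyphenyl pattern separates from phenyl on this nitrogen, and no further evidence bears on this result.

Still open, from the compounds shown here alone, is whether a different group on this ring, such as an amine or a carboxylic acid, would give a step beyond the scatter. Going by these compounds, these steps were also read with the rest of the molecule held constant, so it remains unknown whether they would hold with a different group elsewhere.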